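From 3,4-difluorophenyl to 4-methoxyphenyl on a shared core

The compounds below may be only part of what the source reports. "The series", "measured", "known", "first", "only" and "open" are said of these compounds alone.

Of the compounds shown here, three built on a shared core have been measured in a functional assay on SW-620 cells (Homo sapiens) for cytotoxicity (a lower number here means a stronger inhibitor of growth, a higher number a weaker inhibitor of growth), and two of them returned actual numbers. Compound 1 `COc1ccc(C2=C(c3cc(OC)c(OC)c(OC)c3)CC3CCCN3C2=O)cc1O` gave only a limit, > 100000 nM and no number. Compound 2 `COc1ccc(C2=C(c3ccc(SC)cc3)CC3CCCN3C2=O)cc1OC(=O)C1CCCN1C(=O)OC(C)(C)C` reads 10000 nM while compound 3 `CSc1ccc(C2=C(c3ccc(F)c(F)c3)C(=O)N3CCCC3C2)cc1` reads 200 nM and so holds the lower of the two numbers, with a gap to compound 2 that lies beyond the scatter.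

Compound 4 `COc1ccc(C2=C(c3ccc(SC)cc3)CC3CCCN3C2=O)cc1` has not yet been measured. Within the data shown here, it keeps the 4-(methylsulfanyl)phenyl group of compound 3 and carries 4-methoxyphenyl in place of 3,4-difluorophenyl on a double-bonded ring carbon as its one change. Among the measured compounds shown here, no measured pair isolates a single change, so any forecast is loose. Compound 4 resembles compound 2 more closely on the changed side, and compound 2 sits at 10000 nM in this assay which pulls the expectation upward from compound 3. The expected step is a 2.5-fold higher number from compound 3 to compound 4 (0.40 log units; beyond the scatter) and points to weaker inhibition of growth, a modest move just beyond the scatter. The estimate for compound 4 is 500 nM with 100 nM to 3000 nM as the expected range.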

Compound 4, concentration for 50% growth inhibition: 3000 nM
Estimate against measurement, compound 4: 6.0-fold (0.78 log units) below, and the stated range covers the measured number.
By their numbers in this assay, from the lowest: compound 3; then compound 4; then compound 2. At a limit, above all of these: compound 1.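

Among these compounds, the pair of compound 3 and compound 4 is the first to isolate a single change, and it shows that in this assay the double-bonded ring carbon is sensitive to the group it carries. With the 4-(methylsulfanyl)phenyl group held in place, 4-methoxyphenyl in place of 3,4-difluorophenyl gives a 15-fold higher number from compound 3 to compound 4 (1.18 log units; beyond the scatter), even though the two groups are equal in heavy atoms and each is a six-membered aromatic ring of carbon only. Nothing in the evidence at hand accounts for a step of this size.

A single pair cannot say whether the weaker inhibition of growth follows from losing the two fluorines or from gaining the methoxy group, and a plain phenyl, a 4-fluorophenyl or a 4-hydroxyphenyl on the same carbon would separate those two readings. As far as these compounds go, it also remains open whether the step would hold if the 4-(methylsulfanyl)phenyl group gave way to another group, such as a 4-(dimethylamino)phenyl.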